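A few compounds are considered here, and "the series" means these few. Any claim that something is new, unique, unknown or untested is made for them only; others in the source may bear on it.

Working notes on the cytotoxicity series.

Compound 1 `CC(C)N(Cc1cccc(OCCCCCC(=O)O)c1)C(=O)c1ccc(-c2cccc(N(C)C)c2)cc1` in an ADME assay on BJ cells (Homo sapiens) for cytotoxicity, read by CellTiter-Glo and resazurin assay, with a stated time of 72 h (on this read-out lower numbers stand for an effect already at smaller amounts and higher numbers for an effect only at larger amounts of compound), gives > 26000 nM, which is a limit of the assay and not a number. Compound 2 `CC(C)N(Cc1cccc(OCCCCCC(=O)O)c1)C(=O)c1ccc(-c2ccoc2)cc1` gives in this assay > 26000 nM, again a limit. Compound 3 `CC(C)N(Cc1cccc(OCCCCCC(=O)O)c1)C(=O)c1ccc(-c2ccco2)cc1` gives in this assay > 26000 nM, also a limit. Where compound 1 stands cannot be placed on a scale, since all three values shown are limits; the steps a step that the two limits leave unreadable from compound 1 to compound 2, a step that the two limits leave unreadable from compound 1 to compound 3 and a step that the two limits leave unreadable from compound 2 to compound 3 cannot be sized from the pairs of limits (the limit of > 26000 nM in this assay, at which 3 of the 3 values shown sit).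

Compound 4 `CC(C)N(Cc1cccc(OCCCCCC(=O)O)c1)C(=O)c1ccc(-c2cccc(Oc3ccccc3)c2)cc1` is the next compound to be measured in this assay. Its change from compound 1 is phenoxy in place of dimethylamino on an aromatic carbon. Among the compounds with values here, none of the measured steps touches the phenoxy group, and none of them has a readable size, so there is no measured step that bears directly on this change in this assay. What the series does show is that the shared core with three different groups on the aromatic carbon stayed at the limit, so compound 4 is expected to sit at the limit as well. The estimate for compound 4 is 40000 nM, with a range from 20000 nM to 100000 nM. The expected step that the limit leaves unreadable from compound 1 to compound 4 would then be none beyond the scatter.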

Compound 4, half-maximal effective concentration: > 18700 nM
Compound 4 ended at the assay's limit; the forecaster's own chance of this, stated with the estimate: 85%; the middle value lies beyond the limit too.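

In this assay compound 4 gives > 18700 nM, which is a limit and not a number. Compound 1 gives > 26000 nM, also a limit, so the step between compound 1 and compound 4 cannot be read. The compounds shown leave open whether compound 1, compound 2, compound 3 and compound 4 differ at all in this assay, and at what concentration any of them has an effect.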